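The source may report more compounds than this note shows. Statements on the series, on what has been measured and on what is new or still open speak of the compounds shown alone.

Three ureas built on one shared core have been examined in a functional assay (strain AB) with Danio rerio as the target, read by microscopy, with a stated time of 1 h; a lower number here means that less compound is needed, a higher number that more compound is needed for the effect. Compound 1 `NC(=O)c1c(NC(=O)Nc2ccc(Cl)cc2)sc2c1CCN(C1CCOCC1)C2` gives 2830 nM in this assay, the second highest number of the three. Compound 3 `CCN1CCc2c(sc(NC(=O)Nc3ccc(C(F)(F)F)cc3)c2C(N)=O)C1` gives 2910 nM, a number within the scatter of compound 1, so the two cannot be ordered. Compound 2 `C[N+]1(CC2CC2)CCc2c(sc(NC(=O)Nc3ccc(Cl)cc3)c2C(N)=O)C1` gives 360 nM, a lower number than compound 1 by a margin beyond the scatter. For the measured compounds named here, no two of the measured compounds differ in a single place, so no single measured step is available to guide the next change.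

Compound 4 `CC(C)(C)OC(=O)CCCCN1CCc2c(sc(NC(=O)Nc3ccc(Cl)cc3)c2C(N)=O)C1` has not yet been measured. It differs from compound 1 in one place: 4-(tert-butoxycarbonyl)butyl in place of oxan-4-yl on an amine nitrogen in a ring. Going by the values given here, no measured pair shows what such an exchange does on an amine nitrogen in a ring, so the expectation for compound 4 rests on compound 1 and its value 2830 nM. In this assay compound 4 is expected to give 2000 nM, with a range from 600 nM to 6500 nM. The expected step, a 1.4-fold lower number from compound 1 to compound 4 (0.15 log units; within the scatter), is estimated to stay within the scatter, if anything toward a lower number.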

Compound 4, half-maximal effective concentration: 710 nM
Estimate against measurement, compound 4: 2.8-fold (0.45 log units) above; the measured number falls inside the stated range.
By their numbers in this assay, from the lowest: compounds 2 and 4 (each within the scatter of the next); then compounds 1 and 3 (each within the scatter of the next).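

In this assay, for the compounds shown here, 4-(tert-butoxycarbonyl)butyl in place of oxan-4-yl on an amine nitrogen in a ring gives a 4.0-fold lower number from compound 1 to compound 4 (0.60 log units; beyond the scatter) and provides the first single-place step at this position. It shows that this amine nitrogen can carry a long open chain ending in an ester instead of a ring, and that the number falls beyond the scatter with this exchange. Nothing measured here accounts for this step.

The compounds shown leave open whether the lower number goes with the loss of the ring, the length of the chain or the tert-butoxycarbonyl end. A plain butyl chain and a carboxylic acid at the end of the butyl chain would help to separate these possibilities.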